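The compounds below may be only part of what the source reports. "The series", "measured", "known", "first", "only" and "open" are said of these compounds alone.

Measured in a functional assay on HepG2 cells (Homo sapiens) for cytotoxicity, read by MTT assay, with a stated time of 48 h; on this read-out lower numbers stand for stronger inhibition and higher numbers for weaker inhibition:
Compound 1 `O=c1[nH]c2ccccc2cc1-c1nc2cc(Br)ccc2[nH]1` gives 10800 nM.
Compound 2 `O=c1[nH]c2ccccc2cc1-c1nc2cc([N+](=O)[O-])ccc2[nH]1` gives > 100000 nM, which is a limit of this assay.
Compound 3 `Cc1ccc2[nH]c(=O)c(-c3nc4cc(Cl)ccc4[nH]3)cc2c1` gives 26600 nM.

Compound 3 holds the highest of the two numbers recorded; its nearest neighbour is compound 1, with a lower number that lies beyond the scatter. Compound 2 sits at the limit of > 100000 nM in this assay, at which 1 of the 3 values shown sits.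

Compound 4 `O=c1[nH]c2ccccc2cc1-c1nc2cc(Cl)ccc2[nH]1` arises from compound 3 by hydrogen in place of methyl on an aromatic carbon. Within the data shown here, the single measured step, an at least 9.2-fold higher number from compound 1 to compound 2 (0.96 log units; beyond the scatter), concerns a different ring and a different group, so nothing measured bears directly on this change. With no guide, the step from compound 3 to compound 4 is expected to stay within the scatter, a 1.5-fold lower number from compound 3 to compound 4 (0.17 log units; within the scatter). Compound 4 is therefore estimated at 18000 nM, with a range from 7000 nM to 45000 nM.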

Compound 4, half-maximal inhibitory concentration: 8450 nM
For compound 4 the middle estimate is 2.1-fold (0.33 log units) above the measured one; low and high end bracket the measured number.
By their numbers in this assay, from the lowest: compounds 4 and 1 (each within the scatter of the next); then compound 3. At a limit, above all of these: compound 2.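

In this assay, hydrogen in place of methyl on an aromatic carbon gives a 3.1-fold lower number from compound 3 to compound 4 (0.50 log units; beyond the scatter), so at this position the methyl does not go unnoticed in this pair. Chloro and bromo cannot be told apart: a 1.3-fold lower number from compound 1 to compound 4 (0.11 log units; within the scatter). Chloro in place of nitro gives an at least 11-fold lower number from compound 2 to compound 4 (1.07 log units; beyond the scatter), and this step rests on a limit: the limit of > 100000 nM in this assay, at which 1 of the 4 values shown sits.

Open, from the compounds shown here alone, is whether the methyl step holds with bromo on the shared core. Also open, going by these compounds, is how an ethyl, a methoxy or an amine at the methyl position would read.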